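Methyl in place of hydrogen on the aromatic oxygen

The source may hold more compounds than are shown below. What is called first, only, known or untested is meant among the compounds shown, and "the series" means these compounds.

Compound 1 `O=C(Nc1cccc(-n2cc(-c3ccncc3)c(-c3ccc(Cl)c(O)c3)n2)c1)Nc1ccc(Cl)c(Cl)c1`: in a functional assay on RXF 393 cells (Homo sapiens) for inhibition, read by sulforhodamine B assay, with a stated time of 48 h (a lower number here means a stronger inhibitor of growth, a higher number a weaker inhibitor of growth), compound 1 gives 6400 nM.
Compound 2 `COc1cc(-c2nn(-c3cccc(NC(=O)c4cccc(C(F)(F)F)c4)c3)cc2-c2ccncc2)ccc1Cl`: in this assay compound 2 gives 3150 nM.
Compound 3 `COc1cc(-c2nn(-c3cccc(NC(=O)c4ccccc4)c3)cc2-c2ccncc2)ccc1Cl`: in this assay compound 3 gives 6340 nM.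

Compound 1 and compound 3 give numbers within the scatter of each other; compound 2 gives a lower number than compound 1, a gap beyond the scatter. Among the compounds with values here, the only single-place step measured, a 2.0-fold higher number from compound 2 to compound 3 (0.30 log units; within the scatter), concerns a trifluoromethyl and does not touch the group altered here. Compound 4 `COc1cc(-c2nn(-c3cccc(NC(=O)Nc4ccc(Cl)c(Cl)c4)c3)cc2-c2ccncc2)ccc1Cl` differs from compound 1 by methyl in place of hydrogen on an oxygen on an aromatic ring. Within the data shown here, no measured pair isolates this change; compound 1 and compound 3 differ on this oxygen but also elsewhere, so their values cannot be read as a step. With nothing to suggest a shift, the expected outcome is a 1.2-fold lower number from compound 1 to compound 4 (0.07 log units; within the scatter), within the scatter. Compound 4 is estimated at 5500 nM in this assay, range 2500 nM to 12000 nM.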

Compound 4, concentration for total growth inhibition: 2440 nM
The estimate for compound 4 lay 2.3-fold (0.35 log units) above the measured number; measured number outside the range, below it.
By their numbers in this assay, from the lowest: compounds 4, 2, 3 and 1 (each within the scatter of the next, the first and the last beyond it).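

Methyl on the aromatic oxygen, hydroxy to methoxy, gives a 2.6-fold lower number from compound 1 to compound 4 (0.42 log units; beyond the scatter) in this assay, the first reading of a single-place change at this oxygen. With the methoxy group held, (3,4-dichlorophenyl)amino on the carbonyl carbon gives a 2.6-fold lower number from compound 3 to compound 4 (0.41 log units; beyond the scatter) against phenyl, but a 1.3-fold lower number from compound 2 to compound 4 (0.11 log units; within the scatter) against 3-(trifluoromethyl)phenyl. No supporting measurement accounts for these steps.

Open: how an ethyl group or longer chain on this oxygen, or an amine in its place, would read, and whether the methyl step holds with the other carbonyl substituents.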